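Half-life in the series: hydroxymethyl to methoxy

The source may hold more compounds than are shown below. What is called first, only, known or untested is meant among the compounds shown, and "the series" means these compounds.

Compound 1 `COc1ccc(C[S+]([O-])c2ncccc2C(=O)Nc2ccncc2)c(OCCO)c1` is known in an ADME assay (on this read-out lower numbers stand for a shorter-lived compound and higher numbers for a longer-lived compound), only to a limit: compound 1 gives < 0.02 h, a limit of the assay rather than a number. Compound 2 `COc1cccc(OC)c1C[S+]([O-])c1ncccc1C(=O)Nc1ccncc1` gives 0.66 h in this assay. Compound 3 `COCOc1cc(OC)ccc1C[S+]([O-])c1ncccc1C(=O)Nc1ccncc1` differs from compound 1 by methoxy in place of hydroxymethyl on a saturated chain carbon bound to an oxygen on an aromatic ring. Among the compounds with values here, no measured step between close neighbours exists; the two values shown are all that is known. The expected step from compound 1 to compound 3 in this assay is an at least 10-fold higher number from compound 1 to compound 3 (1.00 log units; beyond the scatter), an increase beyond the usual scatter, since compound 1 sits at the limit of < 0.02 h in this assay, at which 1 of the 2 values shown sits. Compound 3 is expected to give 0.2 h, with a range from 0.03 h to 0.8 h.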

Compound 3, half-life: < 0.02 h
Compound 3 was reported as a limit (the forecaster's own chance of this, stated with the estimate: 25%); middle value at least 10-fold (1.00 log units) from the limit.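

Compound 1 and compound 3 are both limits in this assay, not numbers, so no step between them can be read: the limit of < 0.02 h in this assay, at which 2 of the 3 values shown sit.

As far as these compounds go, whether methoxy in place of hydroxymethyl changes the half-life at all remains open.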